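Swapping the aryl group on a weak nucleoside analogue

The source may hold more compounds than are shown below. What is called first, only, known or untested is meant among the compounds shown, and "the series" means these compounds.

In a functional assay on CCRF-CEM cells (Homo sapiens) for antiproliferative activity, with a stated time of 72 h (on this read-out lower numbers stand for stronger inhibition and higher numbers for weaker inhibition), compound 1 `OC[C@H]1O[C@@H](n2cnc3c(NCc4cccc(F)c4)ncnc32)[C@H](O)[C@@H]1O` gives 4000 nM. Compound 2 `OC[C@H]1O[C@@H](n2cnc3c(NCc4ccccc4Cl)ncnc32)[C@H](O)[C@@H]1O` gives 14500 nM. Compound 3 `COc1ccc(CNc2ncnc3c2ncn3[C@@H]2O[C@H](CO)[C@@H](O)[C@H]2O)c(OC)c1` reaches only a limit of the assay, > 166000 nM, rather than a number; it sits at the limit of > 166000 nM in this assay, at which 1 of the 3 values shown sits. Compound 3 is the weakest of the three, as the steps of an at least 41-fold higher number from compound 1 to compound 3 (1.61 log units; beyond the scatter) and an at least 11-fold higher number from compound 2 to compound 3 (1.05 log units; beyond the scatter) are both large and beyond the scatter. Compound 4 `COc1cccc(CNc2ncnc3c2ncn3[C@@H]2O[C@H](CO)[C@@H](O)[C@H]2O)c1O` differs from compound 3 by 2-hydroxy-3-methoxyphenyl in place of 2,4-dimethoxyphenyl on a saturated chain carbon bound to a nitrogen on an aromatic ring. Going by the values given here, no measured step covers this exchange; the two steps above show only how far the 2,4-dimethoxyphenyl compound lags. Compound 4 is therefore expected to stay weak, with the step of an at least 1.3-fold lower number from compound 3 to compound 4 (0.14 log units; that floor lies within the scatter) estimated as small and uncertain in direction. Compound 4 is estimated at 120000 nM, in the range 30000 nM to 500000 nM.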

Compound 4, half-maximal inhibitory concentration: 300 nM
Compound 4: middle estimate off by 400-fold (2.60 log units), on the high side, outside the stated range (below it).
By their numbers in this assay, from the lowest: compound 4; then compound 1; then compound 2. At a limit, above all of these: compound 3.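

In this assay, the place on a saturated chain carbon bound to a nitrogen on an aromatic ring can hold a much stronger compound than the earlier ones suggested: 2-hydroxy-3-methoxyphenyl gives a 13-fold lower number from compound 1 to compound 4 (1.12 log units; beyond the scatter) and a 48-fold lower number from compound 2 to compound 4 (1.68 log units; beyond the scatter). Two aryl groups with the same count of oxygens can therefore lie very far apart, with an at least 550-fold lower number from compound 3 to compound 4 (2.74 log units; beyond the scatter). Compound 3 stands at a limit, so that step is only a floor: the limit of > 166000 nM in this assay, at which 1 of the 4 values shown sits.

On these data alone, the two groups differ in more than the hydroxyl, so which feature carries the gain stays open. As far as these compounds go, whether an aminophenyl group at this place would behave like 2-hydroxy-3-methoxyphenyl also stays open.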